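The source may report more compounds than this note shows. Statements on the series, on what has been measured and on what is new or still open speak of the compounds shown alone.

Measured so far: compound 1 `CCN(CC)C(=S)SCC1=CCOC1=O` with 121000 nM; compound 2 `CN1CCN(C(=S)SCC2=CCOC2=O)CC1` with 86500 nM; compound 3 `O=C1OCC=C1CSC(=S)Nc1ccc(Cl)cc1` with "not active" (no number reported).

In a functional assay on MCF7 cells (Homo sapiens) for antiproliferative activity, read by MTT assay, with a stated time of 72 h (on this read-out higher numbers stand for weaker inhibition and lower numbers for stronger inhibition), compound 1 gives 121000 nM, the higher of the two numbers recorded. Its nearest neighbour, compound 2, gives 86500 nM in this assay, a difference that lies within the scatter, so the two are not told apart. Compound 3 is reported only as inactive in this assay, without a number.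

Compound 4 `O=C1OCC=C1CSC(=S)N1CCCC1` differs from compound 1 by pyrrolidin-1-yl in place of diethylamino on a thiocarbonyl carbon. Among the measured compounds shown here, the data hold no measured step of this kind. Given the values of compound 1 and compound 2 in this assay, the step from compound 1 to compound 4 is expected to stay within the scatter, in no particular direction, namely a 1.1-fold lower number from compound 1 to compound 4 (0.04 log units; within the scatter). Compound 4 is therefore estimated at 110000 nM in this assay, within a range from 40000 nM to 300000 nM.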

Compound 4, half-maximal inhibitory concentration: 56400 nM
Compound 4: middle estimate off by 2.0-fold (0.29 log units), on the high side; the measured number falls inside the stated range.
By their numbers in this assay, from the lowest: compounds 4, 2 and 1 (each within the scatter of the next, the first and the last beyond it).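

In this assay, among the compounds shown here, replacing diethylamino with pyrrolidin-1-yl on the thiocarbonyl carbon gives a 2.1-fold lower number from compound 1 to compound 4 (0.33 log units; beyond the scatter), the first readable step at this position, and it lies just beyond the scatter. Both groups have the same heavy-atom count, so tying the chain into a ring can shift the number without adding atoms. No measurement available here accounts for the step.

Going by these compounds, whether piperidin-1-yl, with its larger ring, or morpholin-4-yl, with an oxygen in the ring, would continue this shift remains open. So does whether a smaller open-chain group such as dimethylamino would stay close to diethylamino.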